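This account rests on a few compounds, and the source may have more. Where it says the series, first, only, none or still open, it means among the compounds named here.

Working notes on the series. The shared core is kept throughout; the members differ only in the group on the amide carbonyl carbon. Compound 1 `COc1cc(/C=C/C(=O)c2cccc(NC(=O)c3cccs3)c2)ccc1O` carries thiophen-2-yl there, compound 2 `COc1cc(/C=C/C(=O)c2cccc(NC(=O)c3cc(Cl)cc(Cl)c3)c2)ccc1O` carries 3,5-dichlorophenyl and compound 3 `COc1cc(/C=C/C(=O)c2cccc(NC(=O)c3ccc(Cl)cc3Cl)c2)ccc1O` carries 2,4-dichlorophenyl. In a functional assay on HUVEC cells (Homo sapiens) for inhibition, tested at 5 ug/mL (on this read-out higher numbers stand for a stronger effect at the one concentration tested and lower numbers for a weaker effect), compound 1 gives 80%, compound 2 gives 51% and compound 3 gives 51%. Compound 3 therefore stands level with compound 2, the two together forming the lowest pair of the three numbers, with compound 1 clearly above them: the steps run a number 29 percentage points lower from compound 1 to compound 2 (beyond the scatter) and a number 29 percentage points lower from compound 1 to compound 3 (beyond the scatter), whereas no change at the digits printed from compound 2 to compound 3 (within the scatter).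

Compound 4 `COc1cc(/C=C/C(=O)c2cccc(NC(=O)c3ccccc3)c2)ccc1O` is the next member, the change being (phenyl in place of 2,4-dichlorophenyl on a carbonyl carbon). For the measured compounds named here, no measured step covers phenyl against a dichlorophenyl directly. Going by the values given here, what does bear on it is that the two dichlorophenyls are interchangeable within the scatter, and that the one group without chlorine so far, thiophen-2-yl, sits higher than either: a number 29 percentage points lower from compound 1 to compound 2 (beyond the scatter) and a number 29 percentage points lower from compound 1 to compound 3 (beyond the scatter). Phenyl likewise carries no chlorine, so a rise from compound 3 is expected in this assay, though possibly only partway back toward compound 1. Compound 4 is accordingly estimated at 65%, within 45% to 85%, which means an expected step of a number 14 percentage points higher from compound 3 to compound 4 (beyond the scatter).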

Compound 4, a percentage reported as inhibition, at one concentration (the size of the read-out at that concentration, not a potency): 48%
Beside the measured number, compound 4's estimate is 17 percentage points above it; the range from low to high includes it.
By their numbers in this assay, from the lowest: compounds 4, 2 and 3 (each within the scatter of the next); then compound 1.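

In this assay, taking both chlorines off the ring does not separate compound 4 from the dichlorophenyl members: the steps read a number 3 percentage points lower from compound 3 to compound 4 (within the scatter) and a number 3 percentage points lower from compound 2 to compound 4 (within the scatter), so at this carbonyl carbon phenyl, 2,4-dichlorophenyl and 3,5-dichlorophenyl form one level among the compounds shown. The absence of chlorine therefore does not account for the high number of compound 1, since the direct exchange of thiophen-2-yl for phenyl gives a number 32 percentage points lower from compound 1 to compound 4 (beyond the scatter), and among these four members only the thiophen-2-yl compound stands apart, with each of its steps to the others beyond the scatter. Nothing available gives a reason for this separation or for the flat level of the three benzamide members.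

Open, on these data alone, is whether the higher number belongs to thiophen-2-yl alone or extends to other groups at this carbonyl carbon, such as furan-2-yl, a pyridinyl ring or a saturated cyclohexyl ring. Also open, as far as these compounds go, is whether the same order would hold across a range of concentrations, as each read-out here comes from a single tested concentration and is not a potency.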